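Carboxyphenyl to carboxyphenoxy on the shared core

This account rests on a few compounds, and the source may have more. Where it says the series, first, only, none or still open, it means among the compounds named here.

Measured compounds:
- compound 1, `Cc1ccccc1-n1nc(C)c2c1NC(=O)[C@H](C)S[C@@H]2c1ccc(-c2ccoc2)cc1`: 3500 nM
- compound 2, `COc1cccc(-c2ccc([C@H]3S[C@@H](C)C(=O)Nc4c3c(C)nn4-c3ccccc3C)cc2)c1`: 1800 nM
- compound 3, `Cc1ccccc1-n1nc(C)c2c1NC(=O)[C@H](C)S[C@@H]2c1ccc(-c2ccc(C(=O)O)cc2)cc1`: "not active" (no number reported)

The series shares one core and differs only in the group on the aromatic carbon of the outer six-membered ring. In an assay on isolated protein for agonist activity at Bile acid receptor (Homo sapiens), read by AlphaScreen, with a stated time of 30 min (on this read-out lower numbers stand for an effect already at smaller amounts and higher numbers for an effect only at larger amounts of compound), compound 1 gives 3500 nM, and compound 2 gives 1800 nM; the change of 3-methoxyphenyl in place of furan-3-yl gives a 1.9-fold lower number from compound 1 to compound 2 (0.29 log units; within the scatter), so the two cannot be ordered. Compound 3, carrying 4-carboxyphenyl, is recorded in this assay as "not active" (no number reported), with no number for it; on the numbers shown it stands apart from compound 1 and compound 2 only in that it lacks a value.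

Compound 4, `Cc1ccccc1-n1nc(C)c2c1NC(=O)[C@H](C)S[C@@H]2c1ccc(Oc2ccc(C(=O)O)cc2)cc1`, differs from compound 3 by 4-carboxyphenoxy in place of 4-carboxyphenyl on an aromatic carbon. No measured step covers a change of this kind: the only step shown, from compound 1 to compound 2, concerns another group and lies within the scatter. For the measured compounds named here, the sole anchor is compound 3 itself, which gave "not active" (no number reported) in this assay. Compound 4 is therefore expected to remain weak in this assay, with a fair chance that again no number is obtained; its estimated value is 20000 nM, within a range of 5000 nM to 80000 nM.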

Compound 4, half-maximal effective concentration: "not active" (no number reported)
For compound 4 the study gives words and no number; the estimate stays without a comparison.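

No new step can be read from compound 3 to compound 4: in this assay compound 3 gives "not active" (no number reported) and compound 4 gives "not active" (no number reported), so neither supplies a number. Nothing shown bears on this result. The compounds shown leave open whether 4-carboxyphenoxy and 4-carboxyphenyl differ in effect on the shared core.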